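The source may report more compounds than this note shows. Statements on the series, on what has been measured and on what is new or still open speak of the compounds shown alone.

Compound 1 `N#CC1=C(N)Oc2c(c3nc4ccccc4nc3c3ccccc23)C12C(=O)N(Cc1cnnn1-c1ccc(F)cc1)c1ccccc12` in an ADME assay on HUVEC cells (Homo sapiens) for antiproliferative activity, read by MTT assay, with a stated time of 48 h (a lower number here means a stronger inhibitor, a higher number a weaker inhibitor), gives > 50000 nM, a limit of the assay.
Compound 2 `CCOc1ccccc1-n1nncc1CN1C(=O)C2(C(C#N)=C(N)Oc3c2c2nc4ccccc4nc2c2ccccc32)c2ccccc21` in this assay gives > 50000 nM, likewise a limit.
Compound 3 `N#CC1=C(N)Oc2c(N)cc3nc4ccccc4nc3c2C12C(=O)N(Cc1cnnn1-c1ccc(F)cc1)c1ccccc12` in this assay gives > 50000 nM, again a limit and not a number.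

Compound 3 thus stands at the limit of this assay; indeed all three measured values sit there (the limit of > 50000 nM in this assay, at which 3 of the 3 values shown sit), so nothing in the series has yet given a readable number. Within the data shown here, the one step that is computed, a step that the two limits leave unreadable from compound 1 to compound 2, varies the same group on the aromatic nitrogen as the change now considered, yet its size cannot be read because both of its values are limits.

Compound 4 `N#CC1=C(N)Oc2c(N)cc3nc4ccccc4nc3c2C12C(=O)N(Cc1cnnn1-c1ccc([N+](=O)[O-])cc1[N+](=O)[O-])c1ccccc12` differs from compound 3 only in that group: 2,4-dinitrophenyl in place of 4-fluorophenyl on an aromatic nitrogen. Among the measured compounds shown here, no measured step bears readably on this change. With every related compound at the limit (the limit of > 50000 nM in this assay, at which 3 of the 3 values shown sit), the expectation for compound 4 in this assay is that it also remains at the limit, and no step beyond the scatter is expected in either direction. The estimated value for compound 4 is 50000 nM, within 20000 nM to 100000 nM; the expected step is a number no higher from compound 3 to compound 4 (the limit leaves the size open).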

Compound 4, half-maximal inhibitory concentration: > 50000 nM
Compound 4: only a limit was reported; the forecaster's own chance of this, stated with the estimate: 85%; the middle value sits exactly at the limit.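

Among these compounds, compound 3 and compound 4 both stand only as limits, so no step between them can be read: the limit of > 50000 nM in this assay, at which 4 of the 4 values shown sit.
The compounds shown leave open whether any group on the aromatic nitrogen gives a readable number in this assay at all.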